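The compounds below may be only part of what the source reports. "The series", "measured", "known", "first", "only" and "open" are said of these compounds alone.

Measured compounds:
compound 1 `Cc1nc(-c2ccc(Cl)cc2)sc1C(=O)CSc1nc(N)c(C#N)c(-c2ccc(Cl)cc2)n1` — 3420 nM
compound 2 `COc1ccc(-c2nc(C)c(C(=O)CSc3nc(N)c(C#N)c(-c4ccc(Cl)cc4)n3)s2)cc1` — 4540 nM
compound 3 `Cc1nc(-c2ccccc2)sc1C(=O)CSc1nc(-c2ccc(Cl)c(Cl)c2)c(C#N)c(=O)[nH]1` — 65000 nM

In a functional assay on U-87MG ATCC cells for antiproliferative activity against U-87 MG (Homo sapiens), read by MTT assay, with a stated time of 48 h (a lower number here means a stronger inhibitor, a higher number a weaker inhibitor), compound 1 gives the lowest of the three numbers; compound 2 sits within the scatter of it, while compound 3 lies well apart. Compound 4 `COc1ccc(-c2nc(SCC(=O)c3sc(-c4ccc(Cl)cc4)nc3C)nc(N)c2C#N)cc1` has not yet been measured. It differs from compound 1 in one place: methoxy in place of chloro on an aromatic carbon. Within the data shown here, the only measured step of the same exchange of groups is a 1.3-fold higher number from compound 1 to compound 2 (0.12 log units; within the scatter), which did not leave the scatter. On that basis no step beyond the scatter is expected in this assay for compound 4, in either direction. The estimate for compound 4 is therefore 4000 nM, between 1900 nM and 8500 nM, which means an expected 1.2-fold higher number from compound 1 to compound 4 (0.07 log units; within the scatter).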

Compound 4, half-maximal inhibitory concentration: 10600 nM
Beside the measured number, compound 4's estimate is 2.7-fold (0.42 log units) below it, outside the stated range (above it).
By their numbers in this assay, from the lowest: compounds 1 and 2 (each within the scatter of the next); then compound 4; then compound 3.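

Compound 1 carries two 4-chlorophenyl groups, and in this assay the same change to 4-methoxyphenyl does not read alike at the two places. At this position it gives a 3.1-fold higher number from compound 1 to compound 4 (0.49 log units; beyond the scatter), a modest step, while at the other it gave a 1.3-fold higher number from compound 1 to compound 2 (0.12 log units; within the scatter), so the earlier step did not carry over. Nothing available accounts for this difference.

The compounds shown leave open whether a fluoro, a methyl or an amine on this aromatic carbon would stay close to compound 1. They also leave open whether the step follows the loss of chloro or the entry of methoxy.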